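The source may report more compounds than this note shows. Statements on the series, on what has been measured and on what is new or still open speak of the compounds shown alone.

Measured in a functional assay on WiDr cells (Homo sapiens) for antiproliferative activity, read by sulforhodamine B assay, with a stated time of 48 h; on this read-out lower numbers stand for stronger inhibition of growth and higher numbers for weaker inhibition of growth (each value is a limit of the assay, not a number):
- compound 1 `CC(C)(C)[Si](C)(C)O[C@@H]1CCCO[C@@H]1CO` gives > 100000 nM
- compound 2 `CC(C)(C)[Si](C)(C)O[C@@H]1CCCO[C@@H]1/C=C\CO` gives > 100000 nM
- compound 3 `COC(=O)/C=C/[C@H]1OCCC[C@H]1O[Si](C)(C)C(C)(C)C` gives > 100000 nM

Compound 3 has no number of its own and stands with the other two at the limit of > 100000 nM in this assay, at which 3 of the 3 values shown sit. The move to compound 4 `CC(C)(C)[Si](C)(C)O[C@@H]1CCCO[C@@H]1/C=C/C(=O)O` is hydrogen in place of methyl on an oxygen next to a carbonyl group, turning 2-(methoxycarbonyl)ethenyl into 2-carboxyethenyl. For the measured compounds named here, the steps that bear on it, a step that the two limits leave unreadable from compound 1 to compound 3 and a step that the two limits leave unreadable from compound 2 to compound 3, have no readable size and give no direction. No step beyond the scatter is therefore expected in this assay, and the expected step is a number no higher from compound 3 to compound 4 (the limit leaves the size open). For compound 4 the estimated value is 100000 nM, within an expected range of 50000 nM to 200000 nM, most likely reported again as a limit.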

Compound 4, concentration for 50% growth inhibition: > 100000 nM
Compound 4 was reported as a limit; the forecaster's own chance of this, stated with the estimate: 80%; the middle value lies on the limit itself.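

Compound 4 gives > 100000 nM, a limit and not a number. No step from compound 1, compound 2 or compound 3 to compound 4 can be read, and the series sits at one value: the limit of > 100000 nM in this assay, at which 4 of the 4 values shown sit.

The compounds shown leave open whether any group at this place on the shared core gives a measurable value.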